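From 2-hydroxyphenyl to 4-hydroxyphenyl in compound 3

This account rests on a few compounds, and the source may have more. Where it says the series, first, only, none or still open, it means among the compounds named here.

In a functional assay on HepG2 cells (Homo sapiens) for inhibition, read by MTT assay, with a stated time of 72 h (a lower number here means a stronger inhibitor, a higher number a weaker inhibitor), compound 1 `C#CCSc1nc(NCCC(C)C)c2ccncc2n1` gives > 80000 nM, which is a limit. Compound 2 `C#CCSc1nc(Nc2ccccc2O)c2ccncc2n1` gives > 80000 nM, also a limit, and the limit of > 80000 nM in this assay, at which 2 of the 2 values shown sit, sums up the evidence so far. Among the compounds with values here, the one measured step, a step that the two limits leave unreadable from compound 1 to compound 2, therefore has no readable size. Compound 3 `C#CCSc1nc(Nc2ccc(O)cc2)c2ccncc2n1` has 4-hydroxyphenyl in place of 2-hydroxyphenyl on a nitrogen on an aromatic ring. Compound 2, at > 80000 nM, offers only a limit as a starting point, so no step beyond the scatter is expected in this assay. The estimated step is a number no higher from compound 2 to compound 3 (the limit leaves the size open). The expected value for compound 3 is 80000 nM, within an estimated range of 30000 nM to 160000 nM.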

Compound 3, half-maximal inhibitory concentration: > 80000 nM
Compound 3 was reported as a limit; the forecaster's own chance of this, stated with the estimate: 65%; the middle value lies on the limit itself.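

In this assay compound 3 gives > 80000 nM, which is a limit, so its steps from compound 1 and compound 2 cannot be read: the limit of > 80000 nM in this assay, at which 3 of the 3 values shown sit. The compounds shown leave open whether isopentyl, 2-hydroxyphenyl and 4-hydroxyphenyl differ at all in this assay.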